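Moving the aryl group on compound 3's amide nitrogen

A few compounds are considered here, and "the series" means these few. Any claim that something is new, unique, unknown or untested is made for them only; others in the source may bear on it.

Measured so far in a functional assay on T47D cells (Homo sapiens) for inhibition, read by CCK-8 assay, with a stated time of 72 h, tested at 1 uM; a higher number here means more inhibition of growth at the concentration tested, a lower number less inhibition of growth:
- compound 1 `Cc1cccc(NC(=O)C2(C(=O)Nc3ccc(Nc4ncc5cc(C(=O)N(C)C)n(C6CCCC6)c5n4)cc3)CC2)c1`: 45.7%
- compound 2 `COc1ccc(NC(=O)C2(C(=O)Nc3ccc(Nc4ncc5cc(C(=O)N(C)C)n(C6CCCC6)c5n4)cc3)CC2)cc1`: 76.4%
- compound 3 `CN(C)C(=O)c1cc2cnc(Nc3ccc(NC(=O)C4(C(=O)Nc5cccc(Cl)c5)CC4)cc3)nc2n1C1CCCC1`: 39.3%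

Among these, compound 3 gives 39.3%. It sits within the scatter of compound 1, as the step of a number 6.4 percentage points lower from compound 1 to compound 3 (within the scatter) shows, and well under compound 2, as the step of a number 37.1 percentage points lower from compound 2 to compound 3 (beyond the scatter) shows.

The next compound is compound 4 `Cc1ccc(NC(=O)C2(C(=O)Nc3ccc(Nc4ncc5cc(C(=O)N(C)C)n(C6CCCC6)c5n4)cc3)CC2)cc1`, which differs in one place: 4-methylphenyl in place of 3-chlorophenyl on an amide-type nitrogen. The group on the amide-type nitrogen is therefore a 4-methylphenyl in place of a 3-chlorophenyl, and the rest of the molecule is unchanged.

Two kinds of evidence bear on this change. The exchange of chloro for methyl alone gave the step of a number 6.4 percentage points lower from compound 1 to compound 3 (within the scatter), so that part of the change is expected to contribute little. Changing the aryl group on this nitrogen can, however, matter far more, as the large step of a number 30.7 percentage points higher from compound 1 to compound 2 (beyond the scatter) shows. Within the data shown here, no measured compound carries the 4-methylphenyl itself, so this support is indirect and the range stays wide.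

In this assay, a moderate rise is expected for compound 4, estimated as a number 16.7 percentage points higher from compound 3 to compound 4 (beyond the scatter). The estimate for compound 4 is 56%, with an expected range from 40% to 76%.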

Compound 4, percent growth inhibition at one concentration: 47.9%
The estimate for compound 4 lay 8.1 percentage points above the measured number, within the range that was stated.
By their numbers in this assay, from the lowest: compounds 3, 1 and 4 (each within the scatter of the next); then compound 2.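

In this assay, the step of a number 28.5 percentage points lower from compound 2 to compound 4 (beyond the scatter) separates a 4-methoxyphenyl from a 4-methylphenyl at this amide-type nitrogen, so the high number of compound 2 does not carry over to every 4-substituted phenyl group shown. Among these compounds, the step of a number 2.2 percentage points higher from compound 1 to compound 4 (within the scatter) shows that the 4-methylphenyl and 3-methylphenyl groups cannot be told apart here, and the step of a number 8.6 percentage points higher from compound 3 to compound 4 (within the scatter) shows the same for the 4-methylphenyl and 3-chlorophenyl groups, leaving compound 2 as the only compound here set apart from the others by its aryl group. No measured property of these groups is available to explain the difference.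

The compounds shown leave open whether a 3-methoxyphenyl on this nitrogen would match compound 2 or stay with compounds 1, 3 and 4, which would show whether the methoxy group needs the arrangement found in the 4-methoxyphenyl. As far as these compounds go, it also remains open whether a 4-ethoxyphenyl, a 4-hydroxyphenyl or a 4-chlorophenyl would follow compound 2 or compound 4.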